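A few compounds are considered here, and "the series" means these few. Any claim that something is new, unique, unknown or untested is made for them only; others in the source may bear on it.

The compounds measured so far, with their results in a functional assay on PC-3 cells (Homo sapiens) for inhibition, read by MTT assay, with a stated time of 48 h; a lower number here means a stronger inhibitor, a higher number a weaker inhibitor:

Compound 1, `COc1ccc(-c2nc3cc(/C=C4\SC(=O)NC4=O)ccc3[nH]2)cc1OC`, gives 8720 nM.
Compound 2, `COc1cc(-c2nc3cc(/C=C4\SC(=O)N(CC(=O)N5CCCCC5)C4=O)ccc3[nH]2)cc(OC)c1OC`, gives 14700 nM.
Compound 3, `COc1cc(OC)c(-c2nc3cc(/C=C4\SC(=O)N(CC(=O)N5CCCCC5)C4=O)ccc3[nH]2)cc1OC`, returned only a limit, > 50000 nM.

Compound 2 sits alongside compound 1: the two numbers lie within the usual scatter of each other, so no order between them can be claimed. Going by the values given here, compound 3 stands apart only in that its result is a limit rather than a number (the limit of > 50000 nM in this assay, at which 1 of the 3 values shown sits); the one measured step, an at least 3.4-fold higher number from compound 2 to compound 3 (0.53 log units; beyond the scatter), concerns the arrangement of the three methoxy groups on the aryl ring and says nothing about the chain on the ring nitrogen.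

Compound 4, `COc1cc(-c2nc3cc(/C=C4\SC(=O)N(Cc5ccccc5)C4=O)ccc3[nH]2)cc(OC)c1OC`, differs from compound 2 at that chain: phenyl in place of (piperidin-1-yl)carbonyl on a saturated chain carbon bound to an amide-type nitrogen in a ring. Among the compounds with values here, no measured pair in this set varies the group at that position, so there is nothing to anchor the direction or size of the change; the shared core and the trimethoxyphenyl of compound 2 are kept.

Within the data shown here, with no bearing step, the expectation for compound 4 is a number near that of compound 2, with a step of a 1.2-fold lower number from compound 2 to compound 4 (0.09 log units; within the scatter) not beyond the scatter. The estimate for compound 4 in this assay is 12000 nM, within a range from 4000 nM to 40000 nM.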

Compound 4, half-maximal inhibitory concentration: 2500 nM
Beside the measured number, compound 4's estimate is 4.8-fold (0.68 log units) above it; the measured number lies below the stated range.
By their numbers in this assay, from the lowest: compound 4; then compounds 1 and 2 (each within the scatter of the next). At a limit, above all of these: compound 3.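

The chain on the ring nitrogen turns out to be a position that matters: in this assay, putting phenyl in place of (piperidin-1-yl)carbonyl on a saturated chain carbon bound to an amide-type nitrogen in a ring gives a 5.9-fold lower number from compound 2 to compound 4 (0.77 log units; beyond the scatter) in this single pair. Going by these compounds alone, until now, the only measured step concerned the arrangement of the methoxy groups on the aryl ring, so this is the first sign that the chain can also shift the number, here towards a stronger inhibitor. Nothing measured here shows which part of the change from ((piperidin-1-yl)carbonyl)methyl to benzyl accounts for the step, whether the loss of the carbonyl, the loss of the piperidine ring or the arrival of the phenyl ring.

The compounds shown leave open how other groups on this chain would compare, such as a benzyl carrying a chlorine or a methoxy group, a longer chain ending in phenyl, or a chain ending in an amine or a carboxylic acid. They also leave open whether benzyl would give a similar step on the aryl ring of compound 3.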